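Ethoxy for Fluoro: From Compound 1 toward Compound 3

This account rests on a few compounds, and the source may have more. Where it says the series, first, only, none or still open, it means among the compounds named here.

Measured so far:
compound 1 `COc1cc(-n2ncnc2-c2ccc(F)cc2)cc(OC)c1OC` — > 10000 nM
compound 2 `CCOc1ccccc1-c1ncnn1-c1cc(OC)c(OC)c(OC)c1` — > 10000 nM

Both measured compounds were examined in a functional assay on A549 cells (Homo sapiens) for antiproliferative activity, read by MTT assay, with a stated time of 72 h; a higher number here means a weaker inhibitor, a lower number a stronger inhibitor. For compound 1 the value > 10000 nM is a limit of the assay rather than a number. For compound 2 the value > 10000 nM is likewise a limit and not a number. Compound 1 therefore stands at the limit of > 10000 nM in this assay, at which 2 of the 2 values shown sit, and nothing shown places it any higher or lower than that. For the measured compounds named here, no two measured compounds differ in a single place, so no measured step exists between them, and the two limits give no direction to follow.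

Compound 3 `CCOc1ccc(-c2ncnn2-c2cc(OC)c(OC)c(OC)c2)cc1` has not yet been measured in this assay. It differs from compound 1 by ethoxy in place of fluoro on an aromatic carbon. Going by the values given here, with only a limit for compound 1 and no measured step of this kind, the expected step in this assay is a step that the limit leaves unreadable from compound 1 to compound 3, none beyond the scatter. Compound 3 is therefore expected to give about 15000 nM, within 5000 nM to 50000 nM, most likely reported once more as a limit.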

Compound 3, half-maximal inhibitory concentration: 100 nM
Estimate against measurement, compound 3: 150-fold (2.18 log units) above; the whole stated range lies above it.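

Ethoxy in place of fluoro on an aromatic carbon, para to a large group, gives an at least 100-fold lower number from compound 1 to compound 3 (2.00 log units; beyond the scatter) in this assay, so this single change at this place is enough to bring the series off the assay limit. For the compounds shown here, compound 3 is the only one of the three compounds with a number rather than a limit, and the step can be stated only as a minimum: the limit of > 10000 nM in this assay, at which 2 of the 3 values shown sit. Compound 2, which also carries ethoxy on this ring but not para to a large group, stays at a limit of the assay, > 10000 nM, so the presence of ethoxy alone does not bring a number here and its place on the ring counts as well.

The compounds shown do not tell how far the step reaches, since the true value of compound 1 lies somewhere past its limit, and they give no reason for the change. They also leave open whether the result belongs to ethoxy in particular or would hold for a methoxy, a longer chain such as propoxy, or an amine at the same place.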